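A few compounds are considered here, and "the series" means these few. Any claim that something is new, unique, unknown or untested is made for them only; others in the source may bear on it.

Measured compounds in an ADME assay on MT4 cells (Homo sapiens) for cytotoxicity, read by MTT assay, with a stated time of 5 days; on this read-out lower numbers stand for higher toxicity in this test and higher numbers for lower toxicity in this test:

Compound 1 `COc1ccc(-c2cnc(Nc3ccc(C#N)cc3)nc2Oc2c(C)cc(C#N)cc2C)cc1` reaches only a limit of the assay, > 279000 nM.
Compound 2 `Cc1cc(C#N)cc(C)c1Oc1nc(Nc2ccc(C#N)cc2)ncc1-c1ccc(Cl)cc1` gives 72600 nM.
Compound 3 `Cc1cc(C#N)cc(C)c1Oc1nc(Nc2ccc(C#N)cc2)ncc1-c1ccc(N)cc1` gives 310 nM.

Compound 3 stands lowest of the two numbers in this assay; the nearest is compound 2, and that gap is a 230-fold lower number from compound 2 to compound 3 (2.37 log units; beyond the scatter). Against compound 1 the step is an at least 900-fold lower number from compound 1 to compound 3 (2.95 log units; beyond the scatter), resting on (the limit of > 279000 nM in this assay, at which 1 of the 3 values shown sits).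

Compound 4 `Cc1cc(C#N)cc(C)c1Oc1nc(Nc2ccc(C#N)cc2)ncc1-c1ccncc1` differs from compound 3 as follows: pyridin-4-yl in place of 4-aminophenyl on an aromatic carbon.

For the measured compounds named here, the steps that bear on this change are those ending in the amino group of compound 3: a 230-fold lower number from compound 2 to compound 3 (2.37 log units; beyond the scatter) and an at least 900-fold lower number from compound 1 to compound 3 (2.95 log units; beyond the scatter). Both show that the two compounds without the amino group, compound 1 and compound 2, sit far higher than compound 3. Compound 4 also lacks the amino group, so a large step upward in this assay is expected, back toward the region of compound 2; the pyridine nitrogen has no measured parallel here, so the exact size is uncertain. For compound 4 the expected step is a 160-fold higher number from compound 3 to compound 4 (2.21 log units; beyond the scatter), and the estimate is 50000 nM, between 5000 nM and 280000 nM.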

Compound 4, half-maximal cytotoxic concentration: 28000 nM
The estimate for compound 4 lay 1.8-fold (0.25 log units) above the measured number; the measured number falls inside the stated range.
By their numbers in this assay, from the lowest: compound 3; then compound 4; then compound 2. At a limit, above all of these: compound 1.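

In this assay, pyridin-4-yl in place of 4-aminophenyl gives a 90-fold higher number from compound 3 to compound 4 (1.96 log units; beyond the scatter), so a change of the ring itself at this carbon, and not only of the group carried on a phenyl ring, also leaves the low number of compound 3 behind. Compound 3 remains alone at the low end, yet the groups without the amino group are not all equal, as pyridin-4-yl in place of 4-chlorophenyl gives a 2.6-fold lower number from compound 2 to compound 4 (0.41 log units; beyond the scatter). Against compound 1 the step is an at least 9.9-fold lower number from compound 1 to compound 4 (0.99 log units; beyond the scatter), and it rests on a limit of the assay: the limit of > 279000 nM in this assay, at which 1 of the 4 values shown sits.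

As far as these compounds go, whether the low number belongs to the amino group alone stays open, and a hydroxy or a dimethylamino group on the same phenyl ring would bear on that. Also open, from the compounds shown here alone, is what an aminopyridinyl group would give at this position.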